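This account rests on a few compounds, and the source may have more. Where it says the series, first, only, none or still open, it means among the compounds named here.

Measured so far:
compound 1, `COc1ccc(NC(=O)NC2CCN(c3ncnc4[nH]ncc34)CC2)cc1`, with 6370 nM in an assay on isolated protein for inhibition of serine/threonine-protein kinase PAK 1 (Homo sapiens), read by ADP-Glo, with a stated time of 40 min; on this read-out lower numbers stand for stronger inhibition and higher numbers for weaker inhibition;
compound 2, `O=C(Nc1ccc(C(F)(F)F)cc1)NC1CCN(c2ncnc3[nH]ncc23)CC1`, with 7150 nM in this assay.

Compound 1 and compound 2 sit within the scatter of each other, the step being a 1.1-fold higher number from compound 1 to compound 2 (0.05 log units; within the scatter). Compound 3, `O=C(Nc1ccc(F)cc1F)NC1CCN(c2ncnc3[nH]ncc23)CC1`, differs from compound 1 by 2,4-difluorophenyl in place of 4-methoxyphenyl on an amide-type nitrogen. Among the compounds with values here, the one measured step that also alters this phenyl group, a 1.1-fold higher number from compound 1 to compound 2 (0.05 log units; within the scatter), stayed within the scatter, so no step beyond the scatter is expected in this assay. Compound 3 is therefore estimated at 6500 nM, within 2500 nM to 17000 nM, an expected step of a 1.0-fold higher number from compound 1 to compound 3 (0.01 log units; within the scatter).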

Compound 3, half-maximal inhibitory concentration: 1140 nM
For compound 3 the middle estimate is 5.7-fold (0.76 log units) above the measured one, outside the stated range (below it).
By their numbers in this assay, from the lowest: compound 3; then compounds 1 and 2 (each within the scatter of the next).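

In this assay, the group on the amide-type nitrogen can move the number beyond the scatter: 2,4-difluorophenyl in place of 4-methoxyphenyl gives a 5.6-fold lower number from compound 1 to compound 3 (0.75 log units; beyond the scatter). The earlier change to this phenyl group, a 1.1-fold higher number from compound 1 to compound 2 (0.05 log units; within the scatter), stayed within the scatter, so this position responds to some changes and not to others. No measurement at hand explains this difference.

The compounds shown leave open whether both fluorines are needed, as a phenyl group carrying a single fluorine would test. From the compounds shown here alone, how an amine or a carboxylic acid on this ring would fare also remains open.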